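The compounds below may be only part of what the source reports. "The series", "measured", "known", "first", "only" and "open" are said of these compounds alone.

Compound 1 `Cc1ccc(C(=O)N[C@@H](C(=O)N2CCC(c3ccc(Cl)cc3)CC2)C(C)C)cc1` gives 25 nM in an assay on THP-1 cells for displacement of a labelled ligand from C-C chemokine receptor type 1 (Homo sapiens) (on this read-out lower numbers stand for stronger inhibition and higher numbers for weaker inhibition), the lowest of the three numbers measured. Compound 3 `CC(C)[C@@H](NC(=O)C1CCCC1)C(=O)N1CCC(c2ccc(Cl)cc2)CC1`, with cyclopentyl in place of 4-methylphenyl on a carbonyl carbon, gives 70 nM, and compound 2 `CC(C)C(NC(=O)c1ccccc1)C(=O)N1CCC(c2ccc(F)cc2)CC1` gives 423 nM. Within the data shown here, the only step measured in one place is a 2.8-fold higher number from compound 1 to compound 3 (0.45 log units; beyond the scatter), which shows that the group on that carbonyl carbon moves the number. Compound 4 `CC(C)[C@@H](NC(=O)c1cc2ccccc2s1)C(=O)N1CCC(c2ccc(Cl)cc2)CC1` differs from compound 1 by 1-benzothiophen-2-yl in place of 4-methylphenyl on a carbonyl carbon. Among the measured compounds shown here, only the step to compound 3 bears on this change, and there a non-aromatic group entered, so it offers limited guidance for exchanging one aromatic group for another. Compound 4 is therefore expected near compound 1, at 20 nM, between 6 nM and 70 nM. This estimate means a 1.3-fold lower number from compound 1 to compound 4 (0.10 log units; within the scatter), expected to stay within the scatter.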

Compound 4, half-maximal inhibitory concentration: 58 nM
Compound 4: the middle estimate sits 2.9-fold (0.46 log units) below what was measured; the measured number falls inside the stated range.
By their numbers in this assay, from the lowest: compound 1; then compounds 4 and 3 (each within the scatter of the next); then compound 2.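

At this carbonyl carbon, exchanging one aromatic group for another is not neutral: 1-benzothiophen-2-yl in place of 4-methylphenyl gives a 2.3-fold higher number from compound 1 to compound 4 (0.37 log units; beyond the scatter) in this series. The exchange of cyclopentyl for 1-benzothiophen-2-yl gives a 1.2-fold lower number from compound 3 to compound 4 (0.08 log units; within the scatter) and so separates these two groups no further than the scatter, which means an aromatic group here does not by itself keep the number of compound 1. No supporting evidence accounts for this change. Still open, as far as these compounds go, is how a thiophen-2-yl or pyridin-3-yl group on this carbonyl carbon would compare with 4-methylphenyl.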